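A few compounds are considered here, and "the series" means these few. Any claim that something is new, unique, unknown or untested is made for them only; others in the source may bear on it.

Measured so far:
compound 1 `COC1(Cc2ccccc2Br)CCN(c2ccc(C(=O)NS(=O)(=O)c3ccc(N[C@H](CCN(C)C)CSc4ccccc4)c([N+](=O)[O-])c3)cc2)CC1`: 1.5 nM
compound 2 `CN(C)CC[C@H](CSc1ccccc1)Nc1ccc(S(=O)(=O)NC(=O)c2ccc(N3CCC(=Cc4cccnc4)CC3)cc2)cc1[N+](=O)[O-]`: 68 nM
compound 3 `CN(C)CC[C@H](CSc1ccccc1)Nc1ccc(S(=O)(=O)NC(=O)c2ccc(N3CCN(Cc4ccccc4)CC3)cc2)cc1[N+](=O)[O-]`: 39.8 nM

In an assay on isolated protein for displacement of a labelled ligand from Apoptosis regulator Bcl-2 (Homo sapiens), read by fluorescence polarization (a lower number here means a stronger inhibitor, a higher number a weaker inhibitor), compound 3 gives 39.8 nM, the second highest of the three numbers. Compound 2 gives 68 nM, which lies within the scatter of compound 3, whereas compound 1 gives 1.5 nM, a far lower number and beyond the scatter. Compound 4 `CN(C)CC[C@H](CSc1ccccc1)Nc1ccc(S(=O)(=O)NC(=O)c2ccc(N3CCN(Cc4ccccc4-c4cccnc4)CC3)cc2)cc1[N+](=O)[O-]` differs from compound 3 by pyridin-3-yl in place of hydrogen on an aromatic carbon, ortho to a large group. Among the compounds with values here, no measured pair shows this change, so nothing directly tells its size. The account expects a small step toward a lower number in this assay, probably not beyond the scatter. The expected step from compound 3 to compound 4 is a 1.8-fold lower number from compound 3 to compound 4 (0.26 log units; within the scatter). Compound 4 is estimated at 22 nM, with a range from 6 nM to 80 nM.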

Compound 4, inhibition constant: 1 nM
Estimate against measurement, compound 4: 22-fold (1.34 log units) above; measured number outside the range, below it.
By their numbers in this assay, from the lowest: compounds 4 and 1 (each within the scatter of the next); then compounds 3 and 2 (each within the scatter of the next).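

In this assay, pyridin-3-yl in place of hydrogen on an aromatic carbon, ortho to a large group, gives a 40-fold lower number from compound 3 to compound 4 (1.60 log units; beyond the scatter). This is the first change in a single place among these compounds, and it shows that this carbon can strongly affect the number. Nothing measured here explains the size of this step. From the compounds shown here alone, whether phenyl, pyridin-4-yl or a methoxy group on the same carbon would give a similar step remains open. Also open, going by these compounds, is whether pyridin-3-yl would have a comparable effect elsewhere on that phenyl ring.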